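This account rests on a few compounds, and the source may have more. Where it says the series, first, only, none or still open, it means among the compounds named here.

Measured in an ADME assay for metabolic stability, in phosphate buffer, at pH 7.3; on this read-out higher numbers stand for a longer-lived compound and lower numbers for a shorter-lived compound:

- Compound 1 `COc1ccc2c(c1)COP(=O)(OCC1CCC(n3cnc4c(N)ncnc43)O1)O2` gives 23.4 h
- Compound 2 `COc1ccc2c(c1)COP(=O)(OC[C@@H]1C=C[C@H](n3cnc4c(N)ncnc43)O1)O2` gives 14.5 h
- Compound 3 `Nc1ncnc2c1ncn2[C@H]1C=C[C@@H](COP2(=O)OCc3ccccc3O2)O1` gives 10.3 h

Compound 3, at 10.3 h, lies within the scatter of compound 2 and beyond the scatter under compound 1. The next compound to be measured is compound 4 `Cc1cccc2c1OP(=O)(OC[C@@H]1C=C[C@H](n3cnc4c(N)ncnc43)O1)OC2`, which differs from compound 3 in one place, with methyl in place of hydrogen on an aromatic carbon, ortho to a fused ring and meta to a fused ring: methyl in place of hydrogen on an aromatic carbon.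

Among the measured compounds shown here, only one measured step bears on this change. It is a 1.4-fold lower number from compound 2 to compound 3 (0.15 log units; within the scatter), with hydrogen in place of methoxy on an aromatic carbon. For the measured compounds named here, that step stays within the scatter, and it is the sole evidence for a change on this aromatic ring. Going by the values given here, no measured pair involves methyl, so the step offers only a rough guide to size. A small rise is expected on adding the group, and nothing beyond the scatter. The expected step in this assay is a 1.4-fold higher number from compound 3 to compound 4 (0.13 log units; within the scatter). The estimate for compound 4 is 14 h, with an expected range from 8 h to 24 h.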

Compound 4, half-life in the ADME assay: 32.3 h
For compound 4 the middle estimate is 2.3-fold (0.36 log units) below the measured one; measured number above the stated range.
By their numbers in the ADME assay, from the lowest: compounds 3, 2, 1 and 4 (each within the scatter of the next, the first and the last beyond it).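

Among the compounds shown here, in the ADME assay, compound 3 gives 10.3 h and compound 4 gives 32.3 h; methyl in place of hydrogen on this aromatic carbon, ortho to a fused ring and meta to a fused ring, gives a 3.1-fold higher number from compound 3 to compound 4 (0.50 log units; beyond the scatter) and is the only step on this ring that is printed as beyond the scatter. For the compounds shown here, the earlier change on the ring, hydrogen in place of methoxy, gave only a 1.4-fold lower number from compound 2 to compound 3 (0.15 log units; within the scatter) and stayed within the scatter, so the earlier compounds did not show that a substituent of a single heavy atom could shift the half-life this clearly. In a physicochemical assay for lipophilicity (a higher number here means a more lipophilic compound, a lower number a more polar compound), compound 3 gives 0.36 and compound 4 gives 0.63; the same change gives a number 0.27 log units higher from compound 3 to compound 4 (within the scatter) and the partition coefficient therefore shows no clear shift alongside the longer half-life.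

No measurement shown accounts for the rise in half-life. The compounds shown leave open whether the rise belongs to methyl alone or would also appear with a fluorine atom, an amine or a longer chain at this carbon, and whether methyl would give a step of similar size on another aromatic carbon of the ring.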